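A few compounds are considered here, and "the series" means these few. Any claim that something is new, unique, unknown or untested is made for them only; others in the source may bear on it.

Compound 3 `O=S(=O)(NCCCNCc1ccc(Br)cc1)c1cc(C(F)(F)F)cc(C(F)(F)F)c1` gives 1500 nM in a functional assay on BXPC-3 cells (Homo sapiens) for inhibition, read by MTT assay, with a stated time of 72 h (on this read-out higher numbers stand for weaker inhibition of growth and lower numbers for stronger inhibition of growth), the lowest of the three numbers recorded. Compound 1 `O=S(=O)(NCCCNCc1ccc(Cl)c(C(F)(F)F)c1)c1cc(C(F)(F)F)cc(C(F)(F)F)c1` gives 7800 nM in this assay, and compound 2 `O=S(=O)(NCCCNCc1ccccc1)c1cc(C(F)(F)F)cc(C(F)(F)F)c1` gives 13000 nM. The step of a 1.7-fold higher number from compound 1 to compound 2 (0.22 log units; within the scatter) lies within the scatter, whereas a 5.2-fold lower number from compound 1 to compound 3 (0.72 log units; beyond the scatter) and an 8.7-fold lower number from compound 2 to compound 3 (0.94 log units; beyond the scatter) both exceed it, which places compound 3 apart from the other two.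

Compound 4 `COc1cccc(CNCCCNS(=O)(=O)c2cc(C(F)(F)F)cc(C(F)(F)F)c2)c1` differs from compound 3 by 3-methoxyphenyl in place of 4-bromophenyl on a saturated chain carbon bound to an amine nitrogen. Within the data shown here, no recorded step exchanges a bromo for a methoxy group on this ring, so the only guidance comes from the steps around compound 3: taking the bromo away, as in an 8.7-fold lower number from compound 2 to compound 3 (0.94 log units; beyond the scatter) read backwards, weakens inhibition, and swapping the 4-bromophenyl for a differently substituted ring, as in a 5.2-fold lower number from compound 1 to compound 3 (0.72 log units; beyond the scatter) read backwards, does likewise. It is therefore expected that compound 4 moves back toward compounds 1 and 2, with a step of a 4.7-fold higher number from compound 3 to compound 4 (0.67 log units; beyond the scatter) toward a higher number. Compound 4 is estimated at 7000 nM in this assay, with a plausible range from 2000 nM to 25000 nM.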

Compound 4, concentration for 50% growth inhibition: 1700 nM
Estimate against measurement, compound 4: 4.1-fold (0.61 log units) above; measured number below the stated range.
By their numbers in this assay, from the lowest: compounds 3 and 4 (each within the scatter of the next); then compounds 1 and 2 (each within the scatter of the next).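

In this assay the 4-bromophenyl and 3-methoxyphenyl groups give results that cannot be told apart, with a 1.1-fold higher number from compound 3 to compound 4 (0.05 log units; within the scatter), while methoxy in place of hydrogen gives a 7.6-fold lower number from compound 2 to compound 4 (0.88 log units; beyond the scatter), so a lower number than that of the plain phenyl is not tied to bromo alone. Ring substitution as such is no rule either: compound 1 goes against it, as its 4-chloro-3-(trifluoromethyl)phenyl group gives way to 3-methoxyphenyl with a 4.6-fold lower number from compound 1 to compound 4 (0.66 log units; beyond the scatter). Nothing available explains these differences.

Bromo and methoxy each appear at one ring place only, so the part played by their place on the ring stays open. Going by these compounds, the effects of a 3-bromophenyl or 4-methoxyphenyl group, of an amine or carboxylic acid on the ring, and of a longer chain also remain unknown.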